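Bromomethylphenyl Variant of a Furan Thiazolidinedione Agonist

The compounds below may be only part of what the source reports. "The series", "measured", "known", "first", "only" and "open" are said of these compounds alone.

Compound 1 `CCOC(=O)CN1C(=O)S/C(=C\c2ccc(-c3ccc(Cl)cc3Cl)o2)C1=O`: 13600 nM
Compound 2 `CCOC(=O)CN1C(=O)S/C(=C\c2ccc(-c3ccccc3)o2)C1=O`: 10500 nM
Compound 3 `CCOC(=O)CN1C(=O)S/C(=C\c2ccc(-c3ccc(Br)cc3)o2)C1=O`: 40400 nM

In a functional assay on K562 cells for agonist activity at integrin alpha-M/beta-2 (Homo sapiens) (on this read-out higher numbers stand for an effect only at larger amounts of compound and lower numbers for an effect already at smaller amounts), compound 3 holds the highest number of the three, standing a 3.0-fold higher number from compound 1 to compound 3 (0.47 log units; beyond the scatter) and a 3.8-fold higher number from compound 2 to compound 3 (0.59 log units; beyond the scatter). Compound 4 `CCOC(=O)CN1C(=O)S/C(=C\c2ccc(-c3ccc(C)cc3Br)o2)C1=O` carries 2-bromo-4-methylphenyl in place of 4-bromophenyl on an aromatic carbon. Going by the values given here, two measured steps bear on this: adding a bromo in place of hydrogen gave a 3.8-fold higher number from compound 2 to compound 3 (0.59 log units; beyond the scatter), while the doubly substituted ring of compound 1 gave a 3.0-fold higher number from compound 1 to compound 3 (0.47 log units; beyond the scatter) in the other direction. Compound 1 and compound 2 both sit at lower numbers than compound 3. Compound 4 also bears two substituents, so a modest move toward those lower numbers is expected, roughly a 2.2-fold lower number from compound 3 to compound 4 (0.35 log units; beyond the scatter). Compound 4 is therefore estimated at 18000 nM, with a range from 7000 nM to 45000 nM.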

Compound 4, half-maximal effective concentration: 18600 nM
For compound 4 the middle estimate is 1.0-fold (0.01 log units) below the measured one, within the range that was stated.
By their numbers in this assay, from the lowest: compounds 2, 1 and 4 (each within the scatter of the next); then compound 3.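

In this assay, replacing 4-bromophenyl with 2-bromo-4-methylphenyl gives a 2.2-fold lower number from compound 3 to compound 4 (0.34 log units; beyond the scatter) and so shows that a bromo-bearing ring need not sit at the high number of compound 3. Both a 1.8-fold higher number from compound 2 to compound 4 (0.25 log units; within the scatter) and a 1.4-fold higher number from compound 1 to compound 4 (0.14 log units; within the scatter) lie within the scatter, so these three rings cannot be told apart on this read-out. Nothing available accounts for this result. This single step relocates the bromo and adds a methyl at once, leaving open which of the two changes matters. On these data alone, how an amine or a carboxylic acid on this ring would behave also remains open.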